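The source may report more compounds than this note shows. Statements on the series, on what has been measured and on what is new or still open speak of the compounds shown alone.

- compound 1 `Cc1ccc2[nH]c(C(=O)N[C@H]3CN(S(=O)(=O)c4ccccc4)C[C@@H]3C(=O)NC[C@@H]3CCCN3C)cc2c1` gives 31 mL.min-1.g-1 as measured
- compound 2 `Cc1ccc2[nH]c(C(=O)N[C@H]3CN(S(=O)(=O)c4ccccc4)C[C@@H]3C(=O)N[C@@H]3CCCN(C)C3)cc2c1` gives 50 mL.min-1.g-1 as measured

These two numbers come from an ADME assay on microsomes from liver (Homo sapiens) for metabolic stability (a lower number here means slower removal, a higher number faster removal of the compound), and are all that is known so far. Compound 2 at 50 mL.min-1.g-1 stands level with compound 1 once the usual scatter of repeat measurements is allowed for.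

Compound 3 `Cc1ccc2[nH]c(C(=O)N[C@H]3CN(S(=O)(=O)c4ccccc4)C[C@@H]3C(=O)N[C@@H]3CCCNC3)cc2c1` is compound 2 with one change: hydrogen in place of methyl on an amine nitrogen in a ring gives hydrogen in place of methyl on an amine nitrogen in a ring. Among the compounds with values here, only one measured step exists, a 1.6-fold higher number from compound 1 to compound 2 (0.21 log units; within the scatter) in size, and it exchanges (1-methylpyrrolidin-2-yl)methyl for 1-methylpiperidin-3-yl. Both of those groups keep their methyl, so no measurement shows what removing it does. With so little evidence, no step beyond the scatter is expected in this assay and no firm direction can be given. The expected step is a 1.2-fold lower number from compound 2 to compound 3 (0.08 log units; within the scatter) and it stays inside the scatter. For compound 3 the estimated value is 42 mL.min-1.g-1 with an expected range from 19 mL.min-1.g-1 to 90 mL.min-1.g-1 in this measurement.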

Compound 3, intrinsic clearance in microsomes: 3 mL.min-1.g-1
The estimate for compound 3 lay 14-fold (1.15 log units) above the measured number; the whole stated range lies above it.
By their numbers in this assay, from the lowest: compound 3; then compounds 1 and 2 (each within the scatter of the next).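

In this assay, the methyl on the amine nitrogen of the six-membered ring matters far more than the first two compounds could show: exchanging it for hydrogen gives a 17-fold lower number from compound 2 to compound 3 (1.22 log units; beyond the scatter), a large step for the loss of a single carbon. The low number also holds against the other methyl-bearing compound, with a 10-fold lower number from compound 1 to compound 3 (1.01 log units; beyond the scatter), although the step between those two methyl-bearing compounds stayed within the scatter. Nothing available on these compounds accounts for the drop.

On these data alone, it remains open whether the same exchange of methyl for hydrogen on the (1-methylpyrrolidin-2-yl)methyl group would give a step of similar size. Also open, as far as these compounds go, is how an ethyl or an acetyl group on this ring nitrogen would read in this assay.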